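From Pentyl to Cyclopropyl on a Shared Core

The source may hold more compounds than are shown below. What is called first, only, known or untested is meant among the compounds shown, and "the series" means these compounds.

- Compound 1 `C=C1C(=O)O[C@H]2CC3=C[C@H](C/C(C)=C/[C@@H](OC(=O)c4ccc(-c5ccccc5)cc4)[C@H]12)OC3=O`: 3500 nM
- Compound 2 `C=C1C(=O)O[C@H]2CC3=C[C@H](C/C(C)=C/[C@@H](OC(=O)/C=C/c4ccc(C(F)(F)F)cc4)[C@H]12)OC3=O`: 1400 nM
- Compound 3 `C=C1C(=O)O[C@H]2CC3=C[C@H](C/C(C)=C/[C@@H](OC(=O)CCCCC)[C@H]12)OC3=O`: 5900 nM

These values come from a functional assay on NCI-H460 cells (Homo sapiens) for cytotoxicity, read by MTT assay, with a stated time of 48 h; a higher number here means a weaker inhibitor, a lower number a stronger inhibitor. Compound 3, at 5900 nM, lies within the usual scatter of compound 1. Compound 2 gives a lower number than compound 3, and that gap lies beyond the scatter.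

Compound 4 `C=C1C(=O)O[C@H]2CC3=C[C@H](C/C(C)=C/[C@@H](OC(=O)C4CC4)[C@H]12)OC3=O` keeps the shared core and carries cyclopropyl in place of pentyl on a carbonyl carbon. Among the measured compounds shown here, no measured pair of compounds differs in one place only, so the data show no direct precedent for this change. The groups at this place differ widely among the measured compounds, yet compound 2 at 1400 nM and compound 3 at 5900 nM stay fairly close. No step beyond the scatter is therefore expected in this assay, though the number may drift slightly higher. The estimated step is a 1.1-fold higher number from compound 3 to compound 4 (0.04 log units; within the scatter). For compound 4 the estimated value is 6500 nM, with an expected range of 2800 nM to 15000 nM.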

Compound 4, half-maximal inhibitory concentration: 3000 nM
Compound 4: the middle estimate sits 2.2-fold (0.34 log units) above what was measured; low and high end bracket the measured number.
By their numbers in this assay, from the lowest: compound 2; then compounds 4, 1 and 3 (each within the scatter of the next).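

In this assay, among the compounds shown here, the first step that can be read at this place, cyclopropyl in place of pentyl on a carbonyl carbon, is a 2.0-fold lower number from compound 3 to compound 4 (0.29 log units; within the scatter) and so does not separate the two groups. For the compounds shown here, at this place, then, an open pentyl chain and a three-membered ring with fewer heavy atoms cannot be told apart in this cell read-out, a point that the earlier compounds, none of them a single-place pair, could not show. No measurement shown speaks to the reason for this result.

The compounds shown leave open whether an amine or a carboxylic acid carried on this carbonyl carbon would give a step beyond the scatter. Also open, as far as these compounds go, is whether a chain longer than pentyl, or a larger ring such as cyclohexyl, would read alike in this assay as well.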